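The source may report more compounds than this note shows. Statements on the series, on what has been measured and on what is new or still open speak of the compounds shown alone.

Measured in a functional assay on the whole organism with Rattus norvegicus as the target; a lower number here means that less compound is needed, a higher number that more compound is needed for the effect:
- compound 1 `CCn1c(=N)sc2cc(OC(F)(F)F)ccc21`: 5 mg/kg
- compound 2 `C=CCn1c(=N)sc2cc(OC(F)(F)F)ccc21`: 7 mg/kg
- compound 3 `C#CCn1c(=N)sc2cc(OC(F)(F)F)ccc21`: 4 mg/kg

Compound 3 cannot be told apart from the other two, since a 1.3-fold lower number from compound 1 to compound 3 (0.10 log units; within the scatter) and a 1.8-fold lower number from compound 2 to compound 3 (0.24 log units; within the scatter) are both small, as is a 1.4-fold higher number from compound 1 to compound 2 (0.15 log units; within the scatter). Compound 4 `N=c1sc2cc(OC(F)(F)F)ccc2n1CC(=O)O` has carboxy in place of ethynyl on a saturated chain carbon bound to an aromatic nitrogen. For the measured compounds named here, the measured steps only exchange small hydrocarbon groups, and no measured compound carries oxygen in this place, so they offer weak guidance. A clear move towards a higher number is therefore expected, though this is a judgement and not a trend in the data. The expected change is a 5.0-fold higher number from compound 3 to compound 4 (0.70 log units; beyond the scatter). In this assay, compound 4 is estimated at 20 mg/kg, with an expected range from 5 mg/kg to 80 mg/kg.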

Compound 4, dose for half-maximal effect: > 10 mg/kg
Compound 4: a limit, no number; the forecaster's own chance of this, stated with the estimate: 30%; the middle value lies beyond the limit too.
By their numbers in this assay, from the lowest: compounds 3, 1 and 2 (each within the scatter of the next). At a limit, above all of these: compound 4.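

In this assay compound 4 gives a limit and not a number: the limit of > 10 mg/kg in this assay, at which 1 of the 4 values shown sits.

Carboxy on this saturated chain carbon bound to an aromatic nitrogen is the only change here that clearly moves the number, with an at least 2.5-fold higher number from compound 3 to compound 4 (0.39 log units; beyond the scatter). The other two steps, an at least 1.4-fold higher number from compound 2 to compound 4 (0.15 log units; that floor lies within the scatter) and an at least 2.0-fold higher number from compound 1 to compound 4 (0.30 log units; that floor lies within the scatter), have floors that alone do not separate the compounds.

On these data alone, how large the step really is stays open. So does whether an amide, an amine or a longer chain ending in a carboxylic acid would behave like carboxy at this place.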